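Changing One Aromatic Group on a Shared Core

This account rests on a few compounds, and the source may have more. Where it says the series, first, only, none or still open, it means among the compounds named here.

Three compounds share one core and differ only in the aromatic group held on an aromatic carbon of that core. Compound 1 `O=C(O)Cc1sc(C(c2ccc(F)cc2)c2ccc(F)cc2)nc1-c1ccccc1` carries a phenyl there, and in an in vitro functional assay on HEK285-7 cells for antagonist activity at prostaglandin D2 receptor 2 (Homo sapiens), read by BRET and beta-arrestin recruitment (a higher number here means a weaker inhibitor, a lower number a stronger inhibitor), compound 1 gives 240 nM. Compound 2 `COc1cc(-c2nc(C(c3ccc(F)cc3)c3ccc(F)cc3)sc2CC(=O)O)ccn1` carries a 2-methoxypyridin-4-yl instead, and in this assay compound 2 gives 380 nM. Compound 3 `O=C(O)Cc1sc(C(c2ccc(F)cc2)c2ccc(F)cc2)nc1-c1cn[nH]c1` carries a 1H-pyrazol-4-yl, and in this assay compound 3 gives 220 nM. Compound 3 has the lowest of the three numbers, yet every pair sits within the scatter: a 1.1-fold lower number from compound 1 to compound 3 (0.04 log units; within the scatter), a 1.6-fold higher number from compound 1 to compound 2 (0.20 log units; within the scatter) and a 1.7-fold lower number from compound 2 to compound 3 (0.24 log units; within the scatter). On these data none of the three can be called stronger or weaker than another.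

Compound 4 `O=C(O)Cc1sc(C(c2ccc(F)cc2)c2ccc(F)cc2)nc1-c1ccc(Cl)cc1` changes that same group once more: 4-chlorophenyl in place of 1H-pyrazol-4-yl on an aromatic carbon. All three measured steps bear on this change, since each swaps one aromatic group for another on that aromatic carbon, and each stayed within the scatter. Within the data shown here, no measured step involves 4-chlorophenyl, so what the chlorine adds is not known from these data. The expectation is therefore a number for compound 4 close to that of compound 3, with a wider range to allow for the untested group. Compound 4 is expected to give 250 nM in this assay, with a range from 100 nM to 650 nM. This expectation amounts to a step of a 1.1-fold higher number from compound 3 to compound 4 (0.06 log units; within the scatter).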

Compound 4, half-maximal inhibitory concentration: 180 nM
Beside the measured number, compound 4's estimate is 1.4-fold (0.14 log units) above it, within the range that was stated.
By their numbers in this assay, from the lowest: compounds 4, 3, 1 and 2 (each within the scatter of the next, the first and the last beyond it).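

Adding a chlorine to the phenyl of compound 1 is the first change in this series that alters a substituent on the aromatic group rather than replacing the whole group, and in this assay the step is small (a 1.3-fold lower number from compound 1 to compound 4 (0.12 log units; within the scatter)). Replacing the 1H-pyrazol-4-yl, which has a hydrogen-bond donor and a hydrogen-bond acceptor, with 4-chlorophenyl, which has neither, also leaves the number within the scatter (a 1.2-fold lower number from compound 3 to compound 4 (0.09 log units; within the scatter)), so this loss of donor and acceptor brings no measurable change in this pair. Among these compounds, the swap of 2-methoxypyridin-4-yl for 4-chlorophenyl gives the first pair to separate, though only modestly (a 2.1-fold lower number from compound 2 to compound 4 (0.32 log units; beyond the scatter)), which shows that the choice of aromatic group at this position can shift the number slightly beyond the scatter.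

No measurement at hand explains the size of any of these steps. Going by these compounds, it remains open whether a nitrile or an amine in place of the chlorine, or a saturated ring or a longer alkyl chain in place of the whole aromatic group, would move the number further than these aromatic groups do.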